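The source may hold more compounds than are shown below. What is called first, only, known or untested is meant among the compounds shown, and "the series" means these compounds.

Compound 1 `Cc1cn(C)nc1[C@H](C)Nc1c(C(N)=O)nnc2ccc(-c3ccc(OCCCN(C)C)nc3)cc12` gives 0.9 nM in an assay on HT-29 cells for inhibition of Serine-protein kinase ATM (Homo sapiens), read by fluorescence, with a stated time of 1 h; a lower number here means a stronger inhibitor, a higher number a weaker inhibitor.
Compound 2 `C[C@H](Nc1c(C(N)=O)nnc2ccc(-c3ccc(OCCCN4CCCC4)nc3)cc12)C1CCOCC1` gives 1.8 nM in this assay.
Compound 3 `C[C@H](Nc1c(C(N)=O)nnc2ccc(-c3ccc(OCCCN4CCCC4)nc3)cc12)c1ccn(C)n1` gives 1.1 nM in this assay.

Among these three, compound 3 holds the second highest number in this assay, with compound 1 and compound 2 each within the scatter of it. Compound 4 `Cc1cn(C)nc1[C@H](C)Nc1c(C(N)=O)nnc2ccc(-c3ccc(OCCCN4CCCC4)nc3)cc12` differs from compound 3 by methyl in place of hydrogen on an aromatic carbon. No measured step isolates this change: the only step shown, a 1.6-fold lower number from compound 2 to compound 3 (0.21 log units; within the scatter), alters a different group. Compound 1 and compound 3 differ in two places, this methyl and the amine on the chain, yet their two values show no gap beyond the scatter. Compound 4 is therefore expected to land close to compound 3, the expected step being a 1.1-fold lower number from compound 3 to compound 4 (0.04 log units; within the scatter). The estimate for compound 4 is 1 nM, with a range from 0.5 nM to 2.2 nM.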

Compound 4, half-maximal inhibitory concentration in the Serine-protein kinase ATM assay: 0.5 nM
Compound 4: middle estimate off by 2.0-fold (0.30 log units), on the high side, and the stated range covers the measured number.
By their numbers in the Serine-protein kinase ATM assay, from the lowest: compounds 4, 1, 3 and 2 (each within the scatter of the next, the first and the last beyond it).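

Methyl in place of hydrogen, on the aromatic carbon next to the ring atom that bears a large group, produces a change in the Serine-protein kinase ATM assay beyond the scatter: a 2.2-fold lower number from compound 3 to compound 4 (0.34 log units; beyond the scatter). In the Serine-protein kinase ATM assay, 1,4-dimethyl-1H-pyrazol-3-yl in place of oxan-4-yl also gives a change beyond the scatter, with a 3.6-fold lower number from compound 2 to compound 4 (0.56 log units; beyond the scatter). In the Serine-protein kinase ATM assay, pyrrolidin-1-yl in place of dimethylamino stays within the scatter, with a 1.8-fold lower number from compound 1 to compound 4 (0.26 log units; within the scatter). In a physicochemical assay for lipophilicity, using the shake flask method, measured as octanol-water partition, with a stated time of 30 min, at pH 7.4 (a higher number here means a more lipophilic compound, a lower number a more polar compound), compound 3 gives 1.8 and compound 4 gives 2.1; the methyl gives a number 0.30 log units higher from compound 3 to compound 4 (within the scatter) and also stays within it. No evidence here explains the gain from this methyl.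

From the compounds shown here alone, whether an ethyl group or a chlorine atom on this carbon would keep the gain remains open. So does whether the methyl has the same effect when dimethylamino replaces pyrrolidin-1-yl on the chain.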